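Methyl for methoxy on a benzothiazole amide series

The compounds below may be only part of what the source reports. "The series", "measured", "known", "first", "only" and "open" are said of these compounds alone.

The measured compounds and their values:
compound 1, `COc1ccc2nc(NC(=O)c3cn(-c4ccccc4)nc3-c3ccccc3)sc2c1`, 17500 nM
compound 2, `Cc1ccc2nc(NC(=O)c3cn(-c4ccccc4)nc3-c3ccccc3)sc2c1`, 15700 nM
compound 3, `COc1ccc2nc(NC(=O)c3cn(-c4ccccc4)nc3-c3ccc(Cl)cc3)sc2c1`, 29300 nM

All three were tested in a functional assay on PC-3 cells (Homo sapiens) for cytotoxicity, read by MTT assay, with a stated time of 72 h; on this read-out higher numbers stand for weaker inhibition and lower numbers for stronger inhibition. Compound 1 and compound 2 differ in one place, and that difference is methyl in place of methoxy on an aromatic carbon. The step it made is a 1.1-fold lower number from compound 1 to compound 2 (0.05 log units; within the scatter), so the two values are not told apart. Among the measured compounds shown here, compound 3 differs from compound 1 by chloro in place of hydrogen on an aromatic carbon, and the step is a 1.7-fold higher number from compound 1 to compound 3 (0.22 log units; within the scatter); compound 3 has the highest of the three numbers, but no step to either other compound is beyond the scatter.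

Compound 4, `Cc1ccc2nc(NC(=O)c3cn(-c4ccccc4)nc3-c3ccc(Cl)cc3)sc2c1`, has not been measured. It differs from compound 3 by methyl in place of methoxy on an aromatic carbon. For the measured compounds named here, this is the same change as the one from compound 1 to compound 2, at the same place on the same ring. The cores of the two pairs differ as described for compound 1 and compound 3. Because the earlier step of a 1.1-fold lower number from compound 1 to compound 2 (0.05 log units; within the scatter) stayed within the scatter, compound 4 is expected to stand close to compound 3, with an estimated step of a 1.1-fold lower number from compound 3 to compound 4 (0.04 log units; within the scatter). In this assay compound 4 is therefore estimated at 26500 nM, with a likely range from 13000 nM to 55000 nM.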

Compound 4, half-maximal inhibitory concentration: 14500 nM
Estimate against measurement, compound 4: 1.8-fold (0.26 log units) above; the range from low to high includes it.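

In this assay, methyl in place of methoxy on the chloro-bearing core gave a 2.0-fold lower number from compound 3 to compound 4 (0.31 log units; beyond the scatter), while chloro in place of hydrogen on the methyl-bearing core gave a 1.1-fold lower number from compound 2 to compound 4 (0.03 log units; within the scatter). Although only the first of these steps lies beyond the scatter, the methyl change cannot be told apart between the two cores, so this pair does not show that its effect depends on the core: the same change on two cores in this assay, a 1.1-fold lower number (0.05 log units; within the scatter) from compound 1 to compound 2 and a 2.0-fold lower number (0.31 log units; beyond the scatter) from compound 3 to compound 4, 1.8-fold (0.26 log units) apart, within the scatter of two such steps. The chloro change also carried across the two cores without a difference that can be told apart, but two cores are only two cases, and they do not show that either change would carry in the same way to other cores in this series: the same change on two cores in this assay, a 1.7-fold higher number (0.22 log units; within the scatter) from compound 1 to compound 3 and a 1.1-fold lower number (0.03 log units; within the scatter) from compound 2 to compound 4, 1.8-fold (0.26 log units) apart, within the scatter of two such steps.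

On these data alone, what an amine, a carboxylic acid or a longer chain would give in place of methyl on that aromatic carbon remains open, as does what fluoro or a nitrile would give in place of chloro. The four compounds also leave open whether groups on the phenyl ring on the ring nitrogen, such as a hydroxyl or an amine, would move the values in this assay further than these small steps.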